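The source may hold more compounds than are shown below. What is called first, only, known or untested is meant among the compounds shown, and "the series" means these compounds.

Three compounds share a common core and were examined in a functional assay on MDA-MB-468 cells (Homo sapiens) for cytotoxicity, read by sulforhodamine B assay, with a stated time of 48 h, tested at 0.01 uM; a higher number here means a weaker effect of the compound at the concentration tested, a lower number a stronger effect. Compound 1 `COc1cc(-c2cc(/C=C/C(=O)c3ccc(N)cc3)[nH]n2)cc(OC)c1OC` gives 90% in this assay. Compound 2 `COc1ccc(-c2cc(/C=C/C(=O)c3ccc(OC)c(OC)c3)[nH]n2)cc1` gives 87%, and compound 3 `COc1cc(-c2cc(/C=C/C(=O)c3ccc(Cl)c(Cl)c3)[nH]n2)cc(OC)c1OC` gives 94%. Compound 1 therefore stands second highest of the three numbers; its nearest neighbour is compound 2, and its furthest is compound 3, yet both of those gaps are within the scatter of the measurement.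

Among the compounds with values here, the only single-point step among them, a number 4 percentage points higher from compound 1 to compound 3 (within the scatter), concerns the ring on the carbonyl side and leaves the number essentially unchanged.

Compound 4 `COc1ccc(-c2cc(/C=C/C(=O)c3ccc(N)cc3)[nH]n2)cc1OC` differs from compound 1 on the other ring: hydrogen in place of methoxy on an aromatic carbon. Within the data shown here, no measured step covers exactly this change. The nearest guide is compound 2, which carries hydrogen at the same position but also a different pattern on the carbonyl side; its value and that of compound 1 lie within the scatter of each other. With compound 3 likewise showing no movement beyond the scatter, a step of no size beyond the scatter is expected, no change at the digits printed from compound 1 to compound 4 (within the scatter).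

Compound 4 is thus estimated at 90%, within a range from 80% to 98%.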

Compound 4, a percentage reported as activity, at one concentration (the size of the read-out at that concentration, not a potency): 94%
For compound 4 the middle estimate is 4 percentage points below the measured one; measured number inside the range.
By their numbers in this assay, from the lowest: compounds 2, 1, 3 and 4 (each within the scatter of the next).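

Within the data shown here, with hydrogen in place of methoxy on an aromatic carbon, this assay gives a number 4 percentage points higher from compound 1 to compound 4 (within the scatter), the first single-place step on the ring that carries the methoxy groups, since the earlier step concerned only the carbonyl side. This shows that, with the 4-aminophenyl group held constant, the methoxy at this position, ortho to a methoxy group and meta to a large group, can give way to hydrogen with no separation beyond the scatter, so neither of the two single-place steps now shown separates its compounds at this one concentration. No evidence is available that bears on this result.

The compounds shown leave open whether a hydroxyl group, an amine or a longer chain such as ethoxy at this position would give a step beyond the scatter, and whether a fluorine atom would behave as hydrogen does here. They also leave open whether the same exchange of methoxy for hydrogen would read alike alongside the 3,4-dichlorophenyl group of compound 3, and how compound 1 and compound 4 would compare across a range of concentrations.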